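The compounds below may be only part of what the source reports. "The series", "measured", "known", "first", "only" and "open" are said of these compounds alone.

Compound 1 `Cc1ccc(CS/C(=C/c2c(O)cc(O)cc2O)C(=O)c2ccc(Cl)cc2)cc1`: 50000 nM
Compound 2 `O=C(/C(=C\c1ccc(Br)cc1)SCc1ccc(Cl)cc1)c1ccc(Cl)cc1`: 1000 nM
Compound 3 `Cc1ccc(CS/C(=C/c2c[nH]c3ccc(Br)cc23)C(=O)c2ccc(Cl)cc2)cc1`: 1000 nM

All three compounds were tested in a functional assay on DU-145 cells (Homo sapiens) for inhibition, read by trypan blue exclusion, with a stated time of 96 h; on this read-out lower numbers stand for stronger inhibition of growth and higher numbers for weaker inhibition of growth. Compound 3, at 1000 nM, is level with compound 2, and together they give the lowest number of the three. Compound 1 gives a much higher number.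

The next compound, compound 4 `Cc1ccc(CS/C(=C/c2ccc(Br)cc2)C(=O)c2ccc(Cl)cc2)cc1`, has 4-bromophenyl in place of the 5-bromo-1H-indol-3-yl of compound 3, on a double-bonded chain carbon bound to a double-bonded chain carbon. The counted difference is 4-bromophenyl in place of 5-bromo-1H-indol-3-yl on a double-bonded chain carbon bound to a double-bonded chain carbon.

For the measured compounds named here, one measured step bears directly on this place in the molecule: a 50-fold lower number from compound 1 to compound 3 (1.70 log units; beyond the scatter). That step is large, so the group at this place can matter a great deal in this assay. However, it starts from a different group and does not predict this swap. The closer guide is compound 2, which already carries 4-bromophenyl at this place and gives 1000 nM, although it differs from compound 4 elsewhere in the molecule.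

A shift beyond the usual scatter is therefore not expected, and the expected step is no change at the digits printed from compound 3 to compound 4 (within the scatter). Compound 4 is estimated at 1000 nM, with an expected range from 300 nM to 4000 nM.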

Compound 4, concentration for 50% growth inhibition: 10000 nM
Compound 4: middle estimate off by 10-fold (1.00 log units), on the low side, outside the stated range (above it).
By their numbers in this assay, from the lowest: compounds 2 and 3 (each within the scatter of the next); then compound 4; then compound 1.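

The step of a 10-fold higher number from compound 3 to compound 4 (1.00 log units; beyond the scatter) in this assay shows that 5-bromo-1H-indol-3-yl and 4-bromophenyl are not interchangeable on a double-bonded chain carbon bound to a double-bonded chain carbon, even though both carry a bromine. The other end of the molecule also counts: with methyl in place of chloro on an aromatic carbon, the number moves by a 10-fold higher number from compound 2 to compound 4 (1.00 log units; beyond the scatter), so compound 2 did not carry over to compound 4 despite sharing its 4-bromophenyl. The 4-bromophenyl group still gives stronger growth inhibition than 2,4,6-trihydroxyphenyl, with a 5.0-fold lower number from compound 1 to compound 4 (0.70 log units; beyond the scatter), so the three groups at this place now fall in a clear order, with 5-bromo-1H-indol-3-yl first, 4-bromophenyl second and 2,4,6-trihydroxyphenyl last.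

No measurement shown here explains any of these steps. Going by these compounds, it remains open whether the gain from 5-bromo-1H-indol-3-yl depends on its bromine, its hydrogen-bond donor or its extra ring, and how an aminomethyl group or a carboxylic acid would fare on that same chain carbon.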